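The source may report more compounds than this note shows. Statements on the series, on what has been measured and on what is new or still open speak of the compounds shown alone.

Measured compounds in an assay for inhibition of serine/threonine-protein kinase Sgk1 (Homo sapiens), with stated times of 30 min and 60 min, in the presence of a further agent that is not named here; on this read-out lower numbers stand for stronger inhibition and higher numbers for weaker inhibition:
Compound 1, `O=C(NC1CCN(C2CC2)C1)c1cc(-c2ccc(NS(=O)(=O)c3cccc(Cl)c3Cl)cc2)nc2[nH]ncc12`, gives 6 nM.
Compound 2, `NC(=O)c1cc(-c2ccc(NS(=O)(=O)c3cccc(Cl)c3Cl)cc2)nc2[nH]ncc12`, gives 1 nM.
Compound 3, `CCNC(=O)c1cc(-c2ccc(NS(=O)(=O)c3cccc(Cl)c3Cl)cc2)nc2[nH]ncc12`, gives 6 nM.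

All three share one core and differ only in the group on the amide-type nitrogen. Compound 3 stands, together with compound 1, at the highest of the three numbers: no change at the digits printed from compound 1 to compound 3 (within the scatter), while a 6.0-fold higher number from compound 2 to compound 3 (0.78 log units; beyond the scatter) shows that the unsubstituted amide of compound 2 sits lower.

Compound 4, `CN1CC(NC(=O)c2cc(-c3ccc(NS(=O)(=O)c4cccc(Cl)c4Cl)cc3)nc3[nH]ncc23)C1`, carries the change (1-methylazetidin-3-yl in place of ethyl on an amide-type nitrogen). Among the measured compounds shown here, of the measured steps, the one from compound 1 to compound 3 bears most directly on it, since it exchanged a ring-bearing amine substituent for ethyl with no change beyond the scatter; the step of a 6.0-fold higher number from compound 2 to compound 3 (0.78 log units; beyond the scatter) only shows that removing the substituent altogether lowers the number. A ring-bearing amine substituent in place of ethyl is therefore expected to give no step beyond the scatter, a 1.2-fold lower number from compound 3 to compound 4 (0.08 log units; within the scatter). Compound 4 is estimated at 5 nM, with a likely range from 2 nM to 15 nM.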

Compound 4, half-maximal inhibitory concentration: < 1 nM
Compound 4 gave a limit, no number; the forecaster's own chance of this, stated with the estimate: 0%; middle value at least 5.0-fold (0.69 log units) away from the limit.
By their numbers in this assay, from the lowest: compound 2; then compounds 1 and 3 (each within the scatter of the next).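

Compound 4 is reported only as a limit, not as a number: the limit of < 1 nM in this assay, at which 1 of the 4 values shown sits. Even so, the position proves sensitive to which ring is attached: replacing ethyl with 1-methylazetidin-3-yl gives an at least 6.0-fold lower number from compound 3 to compound 4 (0.77 log units; beyond the scatter), and replacing 1-cyclopropylpyrrolidin-3-yl with the same group gives an at least 6.0-fold lower number from compound 1 to compound 4 (0.77 log units; beyond the scatter), so a substituent on the amide-type nitrogen need not raise the number, and two ring-bearing amine substituents can be told apart here, which compound 1 and compound 3 alone did not reveal. The remaining step is a number no higher from compound 2 to compound 4 (the limit leaves the size open).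

The compounds shown do not separate the part played by the four-membered ring from that of the methyl group on its nitrogen. From the compounds shown here alone, the same ring with hydrogen on that nitrogen, or an open-chain amine such as 2-(dimethylamino)ethyl, remains open at this position.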